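Oxime series: dimethylamino for chloro, from compound 2 onward

A few compounds are considered here, and "the series" means these few. Any claim that something is new, unique, unknown or untested is made for them only; others in the source may bear on it.

Compound 1 `O/N=C\C=C\c1ccc(Cl)cc1` is the anchor of the set: in a functional assay on HEK293 cells for agonist activity at transient receptor potential cation channel subfamily A member 1 (Homo sapiens), read by scintillation counting and calcium flux (a lower number here means that less compound is needed, a higher number that more compound is needed for the effect), compound 1 gives 9400 nM. Compound 2 `O/N=C/C=C/c1ccc(Cl)cc1` shares the whole skeleton with it; the only distinction is the fact that compounds 1 and 2 differ only in the configuration as drawn. For compound 2 the read-out in this assay is "not determined" (no result reported), so compound 2 stands without a number of its own, and the figure of compound 1 is the nearest measured point to it. For the measured compounds named here, compound 3 `CC(/C=N/O)=C\c1ccc(Cl)cc1` carries a methyl on the chain and in this assay compound 3 gives 69400 nM, a weaker result than compound 1; no step between two measured compounds is recorded, so the size of that gap is taken from the two values only.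

The next compound, compound 4 `CN(C)c1ccc(/C=C/C=N/O)cc1`, differs from compound 2 by dimethylamino in place of chloro on an aromatic carbon. Going by the values given here, no measured step of this kind exists in the set, so the expectation for this assay rests on compound 1 alone: a change of modest size, in either direction, is expected, not clearly beyond the usual scatter around the value of compound 1. For compound 4 in this assay the estimated value is 12000 nM, with a range from 2500 nM to 60000 nM.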

Compound 4, half-maximal effective concentration: 15900 nM
Compound 4: middle estimate off by 1.3-fold (0.12 log units), on the low side; the range from low to high includes it.
By their numbers in this assay, from the lowest: compounds 1 and 4 (each within the scatter of the next); then compound 3.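

For the compounds shown here, compound 4, at 15900 nM in this assay, gives no new step: its partner compound 2 has no number there, and the exchange of chloro for dimethylamino cannot be read. The compounds shown leave open how far that exchange moves the value in this assay, and whether the configuration as drawn moves it at all.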